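This account rests on a few compounds, and the source may have more. Where it says the series, first, only, none or still open, it means among the compounds named here.

Going by the values given here, in an ADME assay on L6 cells (Rattus norvegicus) for cytotoxicity, read by resazurin assay, with a stated time of 70 h (a higher number here means a weaker inhibitor, a lower number a stronger inhibitor), compound 1 `COc1cc(OC)cc(C(=O)Oc2ccc3c(c2)C(C)=CC(C)(C)N3Cc2ccccc2)c1` gives 24000 nM as the only exact number so far. Compound 2 `COc1cc(OC)cc(C(=O)Oc2ccc3c(c2)C(C)=CC(C)(C)N3Cc2ccc(Cl)cc2)c1` gives > 190000 nM as a limit of the assay, not a number. Compound 3 `CCCCCCCC(=O)Oc1ccc2c(c1)C(C)=CC(C)(C)N2Cc1ccccc1` has heptyl in place of 3,5-dimethoxyphenyl on a carbonyl carbon. Among the compounds with values here, the one measured step (an at least 7.9-fold higher number from compound 1 to compound 2 (0.89 log units; beyond the scatter)) put chloro in place of hydrogen on an aromatic carbon, not on the carbonyl carbon, so it bears only loosely and gives no direction. The expected step therefore stays within the usual scatter (a 1.2-fold lower number from compound 1 to compound 3 (0.08 log units; within the scatter)). In this assay compound 3 is estimated at 20000 nM within an expected range (6000 nM to 90000 nM).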

Compound 3, half-maximal inhibitory concentration: 220000 nM
For compound 3 the middle estimate is 11-fold (1.04 log units) below the measured one, and the stated range ends below it.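

The carbonyl carbon proves to be a sensitive place in this assay: heptyl in place of 3,5-dimethoxyphenyl gives a 9.2-fold higher number from compound 1 to compound 3 (0.96 log units; beyond the scatter). Chloro on the benzyl ring is therefore not the only change that raises the number, and this one leaves the aromatic ring out altogether. Compound 3 sits close to a limit of the assay: the limit of > 190000 nM in this assay, at which 1 of the 3 values shown sits.

This single swap cannot separate the loss of the ring from the loss of the two methoxy groups. On these data alone, how a shorter chain, a plain phenyl or an amine at this carbonyl carbon would read remains open.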